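Ester series: thiophen-2-yl in place of 4-fluorophenyl

This account rests on a few compounds, and the source may have more. Where it says the series, first, only, none or still open, it means among the compounds named here.

Values in an ADME assay on cells (Hepatocyte, Mus musculus) for metabolic stability, with a stated time of 30 min; on this read-out lower numbers stand for a less stable compound and higher numbers for a more stable compound:
- compound 1 `CC(=O)OC1CCC(CN2CCN(c3cc(=O)c4cc(C(F)(F)F)cc([N+](=O)[O-])c4s3)CC2)CC1`: 0%
- compound 2 `O=C(OC1CCC(CN2CCN(c3cc(=O)c4cc(C(F)(F)F)cc([N+](=O)[O-])c4s3)CC2)CC1)c1ccc(C(F)(F)F)cc1`: 28.8%
- compound 3 `O=C(OC1CCC(CN2CCN(c3cc(=O)c4cc(C(F)(F)F)cc([N+](=O)[O-])c4s3)CC2)CC1)c1ccc(F)cc1`: 1.5%

Compound 3 at 1.5% stands within the scatter of compound 1 and clearly apart from compound 2, as this step shows (a number 27.3 percentage points lower from compound 2 to compound 3 (beyond the scatter)). Going by these compounds, compound 4 `O=C(OC1CCC(CN2CCN(c3cc(=O)c4cc(C(F)(F)F)cc([N+](=O)[O-])c4s3)CC2)CC1)c1cccs1` has thiophen-2-yl in place of 4-fluorophenyl on a carbonyl carbon, and its value in this assay is still open. For the measured compounds named here, no measured step makes this exact change. The closest evidence comes from changes at the same carbonyl carbon. One step stayed within the scatter (a number 1.5 percentage points higher from compound 1 to compound 3 (within the scatter)), while another was modest and beyond it (a number 28.8 percentage points higher from compound 1 to compound 2 (beyond the scatter)). Three compounds cannot place thiophen-2-yl firmly, so the likeliest outcome is no step beyond the scatter, with a modest rise still possible. The expected change is small (a number 3.5 percentage points higher from compound 3 to compound 4 (within the scatter)) and carries wide uncertainty. For compound 4 the estimated value is 5% within an expected range of 0% to 20% in this read-out.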

Compound 4, percent of the compound remaining: 1.8%
Beside the measured number, compound 4's estimate is 3.2 percentage points above it; the measured number falls inside the stated range.
By their numbers in this assay, from the lowest: compounds 1, 3 and 4 (each within the scatter of the next); then compound 2.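

In this assay, thiophen-2-yl on the carbonyl carbon cannot be told apart from 4-fluorophenyl (a number 0.3 percentage points higher from compound 3 to compound 4 (within the scatter)) or from methyl (a number 1.8 percentage points higher from compound 1 to compound 4 (within the scatter)). A five-membered aromatic ring with a sulfur atom therefore joins the two groups already close together at this position, while 4-(trifluoromethyl)phenyl alone stands apart (a number 27 percentage points lower from compound 2 to compound 4 (beyond the scatter)), making compound 2 the only exception among the four esters. Nothing measured here accounts for the position of compound 2.

Going by these compounds, whether the separation of compound 2 follows the trifluoromethyl group itself remains open, as a 4-chlorophenyl or 4-cyanophenyl group on the carbonyl carbon, or trifluoromethyl on a thiophen-2-yl ring, would be needed to test it. Also open, on these data alone, is whether an amide in place of the ester would keep these four groups in the same arrangement.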